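A few compounds are considered here, and "the series" means these few. Any claim that something is new, unique, unknown or untested is made for them only; others in the source may bear on it.

Three compounds have been measured so far in a functional assay on MGC-803 cells (Homo sapiens) for antiproliferative activity, read by CCK-8 assay, with a stated time of 72 h (on this read-out higher numbers stand for weaker inhibition and lower numbers for stronger inhibition), with these results
Compound 1 `Nc1ccccc1NC(=O)c1ccc(COc2ccc([N+](=O)[O-])cc2)cc1` gives > 32000 nM (a limit of the assay, not a number)
Compound 2 `CCc1ccc(OCc2ccc(C(=O)Nc3ccccc3N)cc2)cc1` gives 5880 nM
Compound 3 `COc1ccc(OCc2ccc(C(=O)Nc3ccccc3N)cc2)cc1` gives 3480 nM

Compound 3 has one measured number to compare with, and that step reads a 1.7-fold lower number from compound 2 to compound 3 (0.23 log units; within the scatter) so the two stand level. Compound 4 `CC(C)c1ccc(OCc2ccc(C(=O)Nc3ccccc3N)cc2)cc1` differs from compound 3 in one place, isopropyl in place of methoxy on an aromatic carbon which means isopropyl in place of methoxy on an aromatic carbon, para to a large group.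

Two other steps, an at least 5.4-fold lower number from compound 1 to compound 2 (0.73 log units; beyond the scatter) and an at least 9.1-fold lower number from compound 1 to compound 3 (0.96 log units; beyond the scatter) both leave nitro, a group that plays no part in this change, so they offer little guidance. The best guide is compound 2 (5880 nM). It carries ethyl, which like isopropyl is made of carbon only. In this assay the expected step is therefore modest, leaning towards a higher number, and it reads a 1.6-fold higher number from compound 3 to compound 4 (0.20 log units; within the scatter) as an estimate. For compound 4 the estimated value is 5500 nM with an expected range from 2200 nM to 14000 nM in this measurement.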

Compound 4, half-maximal inhibitory concentration: > 32000 nM
Compound 4: no number, only a limit; the forecaster's own chance of this, stated with the estimate: 5%; at least 5.8-fold (0.76 log units) between middle value and limit.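

In this assay compound 4 gives > 32000 nM, which is a limit of the assay and not a number. On this aromatic carbon, para to a large group, the change is therefore far from neutral, as an at least 9.1-fold higher number from compound 3 to compound 4 (0.96 log units; beyond the scatter) shows, and a single extra methyl on the ethyl group is enough to matter, as an at least 5.4-fold higher number from compound 2 to compound 4 (0.73 log units; beyond the scatter) shows. Compound 1 and compound 4 both end at the limit, so the step between them cannot be read: the limit of > 32000 nM in this assay, at which 2 of the 4 values shown sit.

From the compounds shown here alone, how far the true value of compound 4 lies past that limit remains unknown. Also open, going by these compounds, is whether a straight propyl chain, a longer chain or an amine at this position would stay in the range of compound 2 and compound 3 or fall to the limit like compound 4.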